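A Fluoropyridinyl Alkyne Alongside Three Steady Modulators

The source may hold more compounds than are shown below. What is called first, only, known or untested is meant among the compounds shown, and "the series" means these compounds.

Of the compounds shown here, three have been measured in a functional assay on HEK293 cells for positive allosteric modulation of metabotropic glutamate receptor 5 (Rattus norvegicus), read by fluorescence and calcium flux; on this read-out higher numbers stand for larger maximal responses and lower numbers for smaller maximal responses. Compound 1 `C[C@@H](NC(=O)c1ccc(C#Cc2ccccc2)cn1)C(C)(C)O` gives 60.9%, compound 2 `Cc1ccc(C#Cc2ccc(C(=O)N[C@H](C)C(C)(C)O)nc2)cc1` gives 63.1%, and compound 3 `Cc1nc(C#Cc2ccc(C(=O)N[C@H](C)C(C)(C)O)nc2)cs1` gives 66.6%. Compound 3 carries the highest of the three numbers, yet the step of a number 5.7 percentage points higher from compound 1 to compound 3 (within the scatter) and the step of a number 3.5 percentage points higher from compound 2 to compound 3 (within the scatter) both lie within the scatter, as does a number 2.2 percentage points higher from compound 1 to compound 2 (within the scatter), so nothing separates the three. Compound 4 `C[C@@H](NC(=O)c1ccc(C#Cc2cc(F)ccn2)cn1)C(C)(C)O` differs from compound 3 in one place: 4-fluoropyridin-2-yl in place of 2-methyl-1,3-thiazol-4-yl on a triple-bonded carbon. The two earlier steps at this same triple-bonded carbon bear on it, and both stayed within the scatter. Compound 4 is therefore expected to show no step beyond the scatter in this assay, an expected change of a number 3.6 percentage points lower from compound 3 to compound 4 (within the scatter). Compound 4 is estimated at 63%, between 50% and 76%.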

Compound 4, largest response reached (reported as efficacy), in percent of the reference or control that the assay uses: 66.2%
Compound 4: the middle estimate sits 3.2 percentage points below what was measured; measured number inside the range.
By their numbers in this assay, from the lowest: compounds 1, 2, 4 and 3 (each within the scatter of the next).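

In this assay, the steps to the new 4-fluoropyridin-2-yl group are a number 0.4 percentage points lower from compound 3 to compound 4 (within the scatter), a number 3.1 percentage points higher from compound 2 to compound 4 (within the scatter) and a number 5.3 percentage points higher from compound 1 to compound 4 (within the scatter). On this triple-bonded carbon, then, four aromatic groups, among them a six-membered ring with a hetero atom and a fluorine, are not told apart by the maximal response. No measurement shown speaks to why these groups read alike. Still open, on these data alone, is whether a saturated cyclohexyl group in place of the ring, or an amine or carboxylic acid on it, would produce a step beyond the scatter.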